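A hydroxy for a chloro and the half-life

The compounds below may be only part of what the source reports. "The series", "measured", "known", "first", "only" and "open" are said of these compounds alone.

Measured in an ADME assay on microsomes from liver (Homo sapiens) for metabolic stability, read by LC-MS, using NADPH, with a stated time of 10 min, tested at 10 uM; on this read-out lower numbers stand for a shorter-lived compound and higher numbers for a longer-lived compound:
compound 1 `Nc1ncnc2c1c(Oc1cc(O)ccn1)nn2C1CCC(F)(F)CC1`: > 2.41 h (a limit of the assay, not a number)
compound 2 `CC(C)(C)n1nc(Oc2cc(Cl)ccn2)c2c(N)ncnc21`: 1 h

Within the data shown here, compound 2 gives 1 h as the only true number in this small set. The reading for compound 1 is a limit (> 2.41 h).

The step to follow leads to compound 3 `CC(C)(C)n1nc(Oc2cc(O)ccn2)c2c(N)ncnc21`, which has not yet been measured. It changes compound 2 in a single place: hydroxy in place of chloro on an aromatic carbon. In words, hydroxy stands in place of chloro on an aromatic carbon, opposite the ring nitrogen, so that 4-chloropyridin-2-yl becomes 4-hydroxypyridin-2-yl.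

Among the measured compounds shown here, no measured pair isolates this change, so any forecast is thinly supported. Compound 1 also carries 4-hydroxypyridin-2-yl, and its limit of > 2.41 h is the only hint available. On that hint, a longer half-life is expected in this assay, by a modest step near the edge of the scatter. The expected step is a 2.3-fold higher number from compound 2 to compound 3 (0.36 log units; beyond the scatter), and it is only an estimate. For compound 3 the estimated half-life is 2.3 h, with an expected range from 1.1 h to 4.5 h, and the reading may turn out to be a limit.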

Compound 3, half-life: 1.4 h
For compound 3 the middle estimate is 1.6-fold (0.22 log units) above the measured one; the measured number falls inside the stated range.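

In this assay, putting hydroxy in place of chloro on the aromatic carbon opposite the ring nitrogen gives a 1.4-fold higher number from compound 2 to compound 3 (0.15 log units; within the scatter), so this exchange does not separate the two groups on the tert-butyl compounds. The pair sharing 4-hydroxypyridin-2-yl now isolates the other place, where tert-butyl stands in place of 4,4-difluorocyclohexyl on an aromatic nitrogen, and it gives an at least 1.7-fold lower number from compound 1 to compound 3 (0.23 log units; that floor lies within the scatter). That step can be read only as a floor because compound 1 sits at a limit of the assay, not at a number: the limit of > 2.41 h in this assay, at which 1 of the 3 values shown sits.

As far as these compounds go, the true distance between compound 1 and compound 3 therefore remains open, and with it whether the 4,4-difluorocyclohexyl group separates from tert-butyl beyond the scatter. Also open, from the compounds shown here alone, is whether an amine, a methoxy group or a nitrile on the same aromatic carbon would give a half-life that stands apart from those of the chloro and hydroxy compounds.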